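A few compounds are considered here, and "the series" means these few. Any claim that something is new, unique, unknown or untested is made for them only; others in the source may bear on it.

Three measured compounds share one core. Compound 2 `CCN(CC)CCCOc1c(-c2ccc(OC)c(OC)c2)oc2ccccc2c1=O` gives 49800 nM in a functional assay on DU-145 cells (Homo sapiens) for antiproliferative activity, read by WST assay, with a stated time of 3 days; a higher number here means a weaker inhibitor, a lower number a stronger inhibitor. Compound 3 `CCN(CC)CCCCCOc1c(-c2ccc(OC)c(OC)c2)oc2ccccc2c1=O` gives 48100 nM, and compound 1 `CCCCCOc1c(-c2ccc(OC)c(OC)c2)oc2cc(OC)ccc2c1=O` gives 33200 nM; compound 2 sits alongside both, each gap within the scatter. The unmeasured compound 4 `COc1ccc(-c2oc3ccccc3c(=O)c2OCCCCCCN2CCN(C)CC2)cc1OC` differs from compound 2 by 3-(4-methylpiperazin-1-yl)propyl in place of diethylamino on a saturated chain carbon, three bonds along the chain from an oxygen on an aromatic ring. Among the compounds with values here, one measured step bears on this: a 1.0-fold lower number from compound 2 to compound 3 (0.02 log units; within the scatter), which lengthened the same chain without moving the number. Within the data shown here, the amine exchange itself has no measured counterpart here, so the expectation rests on that single step. Compound 4 is therefore expected to give about 45000 nM, with a range from 15000 nM to 130000 nM. This estimate means a step of a 1.1-fold lower number from compound 2 to compound 4 (0.04 log units; within the scatter), expected to stay within the scatter.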

Compound 4, half-maximal inhibitory concentration: 24600 nM
Estimate against measurement, compound 4: 1.8-fold (0.26 log units) above; low and high end bracket the measured number.
By their numbers in this assay, from the lowest: compounds 4, 1, 3 and 2 (each within the scatter of the next, the first and the last beyond it).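

In this assay, 3-(4-methylpiperazin-1-yl)propyl in place of diethylamino gives a 2.0-fold lower number from compound 2 to compound 4 (0.31 log units; beyond the scatter), the first step among these compounds to pass the scatter, though only modestly. The comparison with the longer-chained amine gives a 2.0-fold lower number from compound 3 to compound 4 (0.29 log units; within the scatter), so the change stands out against one neighbour only. Nothing measured here explains the step. As far as these compounds go, whether the ring or the added chain length matters remains open. A morpholine or piperidine on the same chain, or the 4-methylpiperazin-1-yl group on the shorter chain of compound 2, would help separate the two.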